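Closing the Terminal Amine into a Six-Membered Ring

The source may report more compounds than this note shows. Statements on the series, on what has been measured and on what is new or still open speak of the compounds shown alone.

Measured compounds:
compound 1 `CCN(CC)CCCNc1ccnc2cc(Cl)ccc12` — 17900 nM
compound 2 `Clc1ccc2c(NCCCN3CCCC3)ccnc2c1` — 21500 nM

In a functional assay on MCF7 cells (Homo sapiens) for antiproliferative activity, read by sulforhodamine B assay, with a stated time of 48 h (a higher number here means a weaker inhibitor of growth, a lower number a stronger inhibitor of growth), compound 1 gives 17900 nM, the lowest of the two numbers shown, while compound 2 gives 21500 nM. The step of a 1.2-fold higher number from compound 1 to compound 2 (0.08 log units; within the scatter) is the only measured one that speaks to the change at hand, and it did not move the number beyond the scatter.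

Compound 3 `Clc1ccc2c(NCCCN3CCCCC3)ccnc2c1` differs from compound 1 by piperidin-1-yl in place of diethylamino on a saturated chain carbon, three bonds along the chain from a nitrogen on an aromatic ring. This is the same kind of change as from compound 1 to compound 2, only with a ring one carbon larger, so no step beyond the scatter is expected in this assay in either direction. Compound 3 is therefore expected to give about 20000 nM, most likely between 9000 nM and 45000 nM. That estimate amounts to an expected step of a 1.1-fold higher number from compound 1 to compound 3 (0.05 log units; within the scatter), which would stay within the scatter.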

Compound 3, concentration for 50% growth inhibition: 17700 nM
Compound 3: middle estimate off by 1.1-fold (0.05 log units), on the high side; low and high end bracket the measured number.
By their numbers in this assay, from the lowest: compounds 3, 1 and 2 (each within the scatter of the next).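

In this assay, tying the two ethyl arms of diethylamino into piperidin-1-yl leaves the number where it was, with a 1.0-fold lower number from compound 1 to compound 3 (0.00 log units; within the scatter), and widening the ring from pyrrolidin-1-yl to piperidin-1-yl does the same, with a 1.2-fold lower number from compound 2 to compound 3 (0.08 log units; within the scatter). At this place on the chain, the open group and the two rings therefore cannot be told apart by growth inhibition in these cells, and the size of the ring makes no readable difference either. No measurement is at hand that would explain this result.

The compounds shown leave open whether a terminal group such as morpholin-4-yl or 4-methylpiperazin-1-yl would move the number beyond the scatter. They also leave open what a longer chain carrying the same piperidin-1-yl would do in this assay.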